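Swapping a hydantoin for a thienyl sulfide on a shared oxazolidinone core

The source may report more compounds than this note shows. Statements on the series, on what has been measured and on what is new or still open speak of the compounds shown alone.

Compound 1 `COC(=O)CC1CCN(C[C@H]2CN(c3ccc(-n4cc(-c5ccccn5)cn4)c(F)c3)C(=O)O2)CC1`: 1.78
Compound 2 `O=C1O[C@@H](CN2CCC(c3ccc(F)cc3)CC2)CN1c1ccc(-n2cc(-c3ccccn3)cn2)c(F)c1`: 5.78
Compound 3 `O=C1CNC(=O)N1C[C@H]1CN(c2ccc(-n3cc(-c4ccccn4)cn3)c(F)c2)C(=O)O1`: 1.25

In a physicochemical assay for lipophilicity, read by HPLC, measured as octanol-water partition (a lower number here means a more polar compound, a higher number a more lipophilic compound), compound 3 gives the lowest of the three numbers. Its nearest neighbour is compound 1, and the step of a number 0.53 log units lower from compound 1 to compound 3 (beyond the scatter) separates them; compound 2 lies far above both, as the step of a number 4.00 log units higher from compound 1 to compound 2 (beyond the scatter) shows.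

Compound 4 `O=C1O[C@@H](CSc2cccs2)CN1c1ccc(-n2cc(-c3ccccn3)cn2)c(F)c1` is not yet measured. It differs from compound 3 in one place: (thiophen-2-yl)sulfanyl in place of 2,5-dioxoimidazolidin-1-yl on a saturated chain carbon bound to a saturated ring carbon. Within the data shown here, no measured step makes exactly this exchange. The closest guide is a number 4.00 log units higher from compound 1 to compound 2 (beyond the scatter), where an aromatic ring took the place of an ester-bearing chain and the number rose by a large amount. The step of a number 0.53 log units lower from compound 1 to compound 3 (beyond the scatter) shows that the hydantoin end of compound 3 sits at the low end of the series. Because of a number 4.00 log units higher from compound 1 to compound 2 (beyond the scatter), a large rise in this assay is expected when the hydantoin leaves and the thienyl sulfide enters, so the step of a number 3.35 log units higher from compound 3 to compound 4 (beyond the scatter) is estimated to be large and upward. Compound 4 is therefore expected to give about 4.6, within 3.8 to 5.4.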

Compound 4, partition coefficient: 4.29
Estimate against measurement, compound 4: 0.31 log units above; the range from low to high includes it.
By their numbers in this assay, from the lowest: compound 3; then compound 1; then compound 4; then compound 2.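

At the saturated chain carbon bound to a saturated ring carbon, this assay moves by a number 3.04 log units higher from compound 3 to compound 4 (beyond the scatter) when the whole group is exchanged, so a large rise here does not need the piperidine ring that compound 1 and compound 2 share. That step comes with nearly the same size of group, 7 heavy atoms leaving and 6 entering, with the hydrogen-bond donor count going from 1 to 0 and the acceptor count staying at 2, and the same entering group also gives a number 2.51 log units higher from compound 1 to compound 4 (beyond the scatter). Nothing measured here accounts for the size of these steps.

The compounds shown do not separate the sulfide sulfur from the thiophene ring, so a phenyl sulfide or a thienyl ether on this carbon remains an open comparison. Also open, going by these compounds, is where a carboxylic acid or a primary amine on this carbon would fall.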